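Swapping the aryl group on a trimethoxyphenyl pyrimidine core

This account rests on a few compounds, and the source may have more. Where it says the series, first, only, none or still open, it means among the compounds named here.

Of the compounds shown here, three sharing one core have been tested in a functional assay on HCT-116 cells (Homo sapiens) for inhibition, read by MTT assay, with a stated time of 48 h; a higher number here means a weaker inhibitor, a lower number a stronger inhibitor. Compound 1 `COc1cc(-c2cc(-c3ccc(N)cc3)nc(-c3ccccc3)n2)cc(OC)c1OC` gives 12300 nM, compound 2 `COc1cc(-c2cc(-c3cccs3)nc(-c3ccccc3)n2)cc(OC)c1OC` gives 17000 nM, and compound 3 `COc1cc(-c2cc(-c3ccc(Cl)cc3)nc(-c3ccccc3)n2)cc(OC)c1OC` gives 7980 nM, the lowest of the three numbers, close to compound 1 and further from compound 2. Compound 4 `COc1ccc(-c2cc(-c3cc(OC)c(OC)c(OC)c3)nc(-c3ccccc3)n2)c(OC)c1` differs from compound 3 by 2,4-dimethoxyphenyl in place of 4-chlorophenyl on an aromatic carbon. Among the compounds with values here, two measured steps touch the same position: replacing amino with chloro gave a 1.5-fold lower number from compound 1 to compound 3 (0.19 log units; within the scatter), and replacing thiophen-2-yl with 4-chlorophenyl gave a 2.1-fold lower number from compound 2 to compound 3 (0.33 log units; beyond the scatter). Changes at this position have so far moved this assay only little, so a small step, probably toward a higher number, is expected: a 1.4-fold higher number from compound 3 to compound 4 (0.14 log units; within the scatter). Compound 4 is therefore estimated at 11000 nM, within a range from 4500 nM to 27000 nM.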

Compound 4, half-maximal inhibitory concentration: > 25000 nM
Compound 4: only a limit was reported; the forecaster's own chance of this, stated with the estimate: 5%; at least 2.2-fold (0.35 log units) between middle value and limit.
By their numbers in this assay, from the lowest: compounds 3, 1 and 2 (each within the scatter of the next, the first and the last beyond it). At a limit, above all of these: compound 4.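

In this assay, compound 4 gives only a limit rather than a number: the limit of > 25000 nM in this assay, at which 1 of the 4 values shown sits. Even so, this position proves able to move the read-out more than the earlier swaps showed, with 2,4-dimethoxyphenyl giving an at least 3.1-fold higher number from compound 3 to compound 4 (0.49 log units; beyond the scatter). The comparisons with the other two groups are floors only, so they show no clear separation yet: an at least 2.0-fold higher number from compound 1 to compound 4 (0.30 log units; that floor lies within the scatter), and an at least 1.4-fold higher number from compound 2 to compound 4 (0.16 log units; that floor lies within the scatter).

From the compounds shown here alone, how far the true value of compound 4 lies beyond its limit stays open, as does whether both methoxy groups matter. What an amine-bearing chain or a carboxylic acid on this phenyl ring would do is also unknown.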